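Urea aryl swap on a shared anticancer core

A few compounds are considered here, and "the series" means these few. Any claim that something is new, unique, unknown or untested is made for them only; others in the source may bear on it.

Compound 2 `Cc1ccc(NC(=O)Nc2nc(Nc3ccccc3)cc(Sc3c[nH]c4ccccc34)n2)cc1` belongs to a small set of two compounds sharing one core and differing only in the aryl group on the urea nitrogen. In a functional assay on PC-3 cells (Homo sapiens) for inhibition, with a stated time of 72 h (a lower number here means a stronger inhibitor, a higher number a weaker inhibitor), compound 2 gives 18500 nM. Compound 1 `O=C(Nc1ccccc1)Nc1nc(Nc2ccccc2)cc(Sc2c[nH]c3ccccc23)n1` carries a plain phenyl there, and in this assay compound 1 gives 26400 nM. The only measured step, a 1.4-fold lower number from compound 1 to compound 2 (0.15 log units; within the scatter), is therefore within the scatter, so the two numbers cannot be told apart; compound 2 has the lower of the two numbers but no real order is shown.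

Compound 3 `Cc1cc(Cl)ccc1NC(=O)Nc1nc(Nc2ccccc2)cc(Sc2c[nH]c3ccccc23)n1` is the next change: 4-chloro-2-methylphenyl in place of 4-methylphenyl on an amide-type nitrogen. The step from compound 2 to compound 3 keeps the methyl on the ring and adds a chlorine, so it is a somewhat larger alteration than the earlier one. Going by the values given here, no measured step involves a chlorine, and the single available step, a 1.4-fold lower number from compound 1 to compound 2 (0.15 log units; within the scatter), lay within the scatter. On this basis the step of a 1.2-fold lower number from compound 2 to compound 3 (0.09 log units; within the scatter) is expected to be small, with no change beyond the scatter. Compound 3 is estimated at 15000 nM, within a range of 5000 nM to 45000 nM.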

Compound 3, half-maximal inhibitory concentration: 41900 nM
Estimate against measurement, compound 3: 2.8-fold (0.45 log units) below; the measured number falls inside the stated range.
By their numbers in this assay, from the lowest: compounds 2, 1 and 3 (each within the scatter of the next, the first and the last beyond it).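

In this assay this position on the urea now shows its first step beyond the scatter, as 4-chloro-2-methylphenyl in place of 4-methylphenyl on an amide-type nitrogen gives a 2.3-fold higher number from compound 2 to compound 3 (0.36 log units; beyond the scatter) and so a modest but real difference between the two compounds. Set against the plain phenyl, the same group gives a 1.6-fold higher number from compound 1 to compound 3 (0.20 log units; within the scatter) within the scatter, so the two numbers cannot be told apart and the position shows a real difference only between the 4-methylphenyl and the 4-chloro-2-methylphenyl compounds. The change alters the ring in more than one way at once, with a chlorine entering and the methyl named at a different position, so the step cannot be divided between those parts, and nothing measured here accounts for it.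

The compounds shown leave open how 4-chlorophenyl or 2-methylphenyl, each carrying only one of the two substituents, would read at this position, which would separate the parts of the change. Also open, as far as these compounds go, is whether a different kind of group on this nitrogen, such as a pyridine ring or a phenyl ring bearing a carboxylic acid or an amine, would produce a larger step than those seen so far.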